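This account rests on a few compounds, and the source may have more. Where it says the series, first, only, none or still open, it means among the compounds named here.

In an ADME assay on L02 cells (Homo sapiens) for cytotoxicity, read by MTT assay, with a stated time of 48 h (a higher number here means a weaker inhibitor, a lower number a stronger inhibitor), compound 2 (`CCn1c(C(=O)NCCN)ccc1C(CC)(CC)c1ccc(OCC(O)C(C)(C)C)c(C)c1`) gives 2400 nM and compound 1 (`CCN(CC)CCNC(=O)c1ccc(C(CC)(CC)c2ccc(OCC(O)C(C)(C)C)c(C)c2)n1CC`) gives 2500 nM. For the measured compounds named here, these two numbers lie within the scatter of each other, so compound 2 stands level with the only other measured compound.

Compound 3 (`C=CCN(C)C(=O)c1ccc(C(CC)(CC)c2ccc(OCC(O)C(C)(C)C)c(C)c2)n1CC`) differs from compound 2 as follows: allyl(methyl)amino in place of (2-aminoethyl)amino on a carbonyl carbon. In words, this is allyl(methyl)amino in place of (2-aminoethyl)amino on a carbonyl carbon.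

Going by the values given here, only one measured step bears on this change, and only loosely. That step, a 1.0-fold lower number from compound 1 to compound 2 (0.02 log units; within the scatter), is amino in place of diethylamino on a saturated chain carbon, two bonds along the chain from an amide-type nitrogen, and it stays within the scatter. Neither measured compound carries allyl(methyl)amino on the carbonyl carbon, so the size of the new step is not directly supported by the data. A modest move to a higher number is the working expectation, held with low confidence.

The expected step is a 2.1-fold higher number from compound 2 to compound 3 (0.32 log units; beyond the scatter). For compound 3 the estimated value is 5000 nM, with an expected range of 1800 nM to 20000 nM.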

Compound 3, half-maximal inhibitory concentration: 6300 nM
Compound 3: the middle estimate sits 1.3-fold (0.10 log units) below what was measured; the measured number falls inside the stated range.
By their numbers in this assay, from the lowest: compounds 2 and 1 (each within the scatter of the next); then compound 3.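

In this assay, for the compounds shown here, the carbonyl carbon is the first place in this short series where a change moves the number beyond the scatter: allyl(methyl)amino in place of (2-aminoethyl)amino gives a 2.6-fold higher number from compound 2 to compound 3 (0.42 log units; beyond the scatter), and allyl(methyl)amino in place of (2-(diethylamino)ethyl)amino gives a 2.5-fold higher number from compound 1 to compound 3 (0.40 log units; beyond the scatter). Compounds 1 and 2 stand level, so the terminal amino and diethylamino ends do not separate here, while both steps to compound 3 are modest and of similar size in the same direction. The entering group has no hydrogen-bond donors and carries a double bond outside aromatic rings, but nothing at hand measures a property that would account for the step.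

Compound 3 differs from compound 1 and compound 2 in several features at once, so these compounds cannot show which feature of allyl(methyl)amino goes with the higher number. Open as well is how the number responds to a longer chain such as (3-aminopropyl)amino, or to a hydroxyl-ended chain such as (2-hydroxyethyl)amino, on the same carbonyl carbon.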